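Taking a Methyl Away from Compound 1

The source may hold more compounds than are shown below. What is called first, only, known or untested is meant among the compounds shown, and "the series" means these compounds.

Compound 1 `Cc1cc(C)cc(OCc2nc3ccccc3[nH]2)c1` gives 3.5
Compound 2 `Cc1cc(OCc2nc3ccccc3[nH]2)cc(C)c1Cl` gives 4.43

Compound 1 stands lowest of the two numbers in a physicochemical assay for lipophilicity; a lower number here means a more polar compound, a higher number a more lipophilic compound. Among the compounds with values here, the only measured step is a number 0.93 log units higher from compound 1 to compound 2 (beyond the scatter), with chloro in place of hydrogen on an aromatic carbon. Compound 3 `Cc1cccc(OCc2nc3ccccc3[nH]2)c1` differs from compound 1 by hydrogen in place of methyl on an aromatic carbon. Within the data shown here, no measured step shows this exchange, so the guide is indirect. Given a number 0.93 log units higher from compound 1 to compound 2 (beyond the scatter), where hydrogen was the group that left, a smaller step the opposite way is expected in this assay. The expected step is a number 0.50 log units lower from compound 1 to compound 3 (beyond the scatter). Compound 3 is estimated at 3, with an expected range from 2.65 to 3.35.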

Compound 3, partition coefficient: 3.14
Compound 3: the middle estimate sits 0.14 log units below what was measured; measured number inside the range.
By their numbers in this assay, from the lowest: compound 3; then compound 1; then compound 2.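

Within the data shown here, replacing one methyl with hydrogen gives a number 0.36 log units lower from compound 1 to compound 3 (beyond the scatter) in this assay, the first measured step for a change at this position. The step is beyond the scatter, so this single methyl is enough to shift the reading, and the change runs in the opposite direction to the chloro exchange in the earlier step. No measurement here explains why the number moves. The compounds shown leave open how an ethyl or methoxy group on this aromatic carbon would read. They also leave open whether replacing the remaining methyl with hydrogen would give a step of similar size.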